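A few compounds are considered here, and "the series" means these few. Any claim that something is new, unique, unknown or untested is made for them only; others in the source may bear on it.

In a functional assay on DU-145 cells (Homo sapiens) for cytotoxicity, read by ELISA, with a stated time of 4 days (on this read-out higher numbers stand for weaker inhibition and lower numbers for stronger inhibition), compound 1 `Clc1ccc(-c2cc(-c3ccoc3)cc(-c3ccco3)n2)s1` gives 17200 nM and compound 2 `Clc1cccc(-c2cc(-c3ccoc3)cc(-c3ccc(Cl)s3)n2)c1` gives 23000 nM so these two numbers stand within the scatter of each other. Compound 3 `Clc1ccc(-c2cc(-c3ccoc3)cc(-c3cccnc3)n2)s1` differs from compound 2 by a single swap: pyridin-3-yl in place of 3-chlorophenyl on an aromatic carbon with pyridin-3-yl in place of 3-chlorophenyl on an aromatic carbon. Within the data shown here, the one measured step at this place is a 1.3-fold higher number from compound 1 to compound 2 (0.13 log units; within the scatter) and it stayed within the scatter. With nothing larger seen there, the expected change is a 1.2-fold lower number from compound 2 to compound 3 (0.06 log units; within the scatter) and no shift beyond the scatter is expected in either direction. In this assay compound 3 is estimated at 20000 nM with a range from 8000 nM to 50000 nM as its likely span.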

Compound 3, half-maximal inhibitory concentration: 18500 nM
Compound 3: the middle estimate sits 1.1-fold (0.03 log units) above what was measured, and the stated range covers the measured number.
By their numbers in this assay, from the lowest: compounds 1, 3 and 2 (each within the scatter of the next).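

Swapping the 3-chlorophenyl for pyridin-3-yl, which brings a ring nitrogen and a hydrogen-bond acceptor, gives in this assay a 1.2-fold lower number from compound 2 to compound 3 (0.09 log units; within the scatter). Compared with furan-2-yl at the same position, pyridin-3-yl gives a 1.1-fold higher number from compound 1 to compound 3 (0.03 log units; within the scatter). Three different aromatic rings at this position, one of carbon only and two with a hetero atom, therefore read alike within the scatter, and no measurement offers any explanation for this. Still open, going by these compounds, is whether a non-aromatic group, such as an amine or a carboxylic acid, would move the number beyond the scatter at this position.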